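The source may report more compounds than this note shows. Statements on the series, on what has been measured and on what is new or still open speak of the compounds shown alone.

Compound 1, `Fc1cccc(NC(=S)N/N=C/c2ccc3ccccc3n2)c1`: 74700 nM
Compound 2, `S=C(N/N=C/c1ccc2ccccc2n1)Nc1cccc(Cl)c1`: 48100 nM
Compound 3, `Cc1ccc(NC(=S)N/N=C/c2ccc3ccccc3n2)cc1`: 85500 nM

These three share one core and differ only in the ring attached to the amide-type nitrogen. In a functional assay on HT-29 cells (Homo sapiens) for antiproliferative activity, read by sulforhodamine B assay, with a stated time of 72 h (on this read-out higher numbers stand for weaker inhibition and lower numbers for stronger inhibition), their numbers lie close together: the steps of a 1.1-fold higher number from compound 1 to compound 3 (0.06 log units; within the scatter) and a 1.8-fold higher number from compound 2 to compound 3 (0.25 log units; within the scatter) are within the scatter, as is a 1.6-fold lower number from compound 1 to compound 2 (0.19 log units; within the scatter), so compound 3 stands among equals rather than apart. Compound 4, `Fc1ccc(NC(=S)N/N=C/c2ccc3ccccc3n2)cc1`, arises from compound 3 by fluoro in place of methyl on an aromatic carbon. Within the data shown here, no measured step makes exactly this swap; the nearest are a 1.1-fold higher number from compound 1 to compound 3 (0.06 log units; within the scatter) and a 1.8-fold higher number from compound 2 to compound 3 (0.25 log units; within the scatter), where halogen-bearing rings and the methyl-bearing ring gave numbers within the scatter of each other. A step of a 1.1-fold lower number from compound 3 to compound 4 (0.03 log units; within the scatter) is therefore expected, nothing beyond the scatter. Compound 4 is estimated at 80000 nM, between 35000 nM and 180000 nM.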

Compound 4, half-maximal inhibitory concentration: 28500 nM
Estimate against measurement, compound 4: 2.8-fold (0.45 log units) above; the measured number lies below the stated range.
By their numbers in this assay, from the lowest: compounds 4, 2, 1 and 3 (each within the scatter of the next, the first and the last beyond it).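

In this assay the ring on the amide-type nitrogen now shows a real difference: fluoro in place of methyl gives (a 3.0-fold lower number from compound 3 to compound 4 (0.48 log units; beyond the scatter)), and shifting the fluoro on the ring gives (a 2.6-fold lower number from compound 1 to compound 4 (0.42 log units; beyond the scatter)), so both the group and its place count here. The 4-fluorophenyl and 3-chlorophenyl rings stay unseparated (a 1.7-fold lower number from compound 2 to compound 4 (0.23 log units; within the scatter)). No measurement shown explains these steps. On these data alone, whether chloro, an amine or a carboxylic acid in that same place, para to a large group, would match fluoro remains open.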